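This account rests on a few compounds, and the source may have more. Where it says the series, first, only, none or still open, it means among the compounds named here.

Compound 3 `COc1cccc(NC(=O)/C=C/c2coc3cc(OC)ccc3c2=O)c1` gives 19200 nM in a functional assay on HeLa cells (Homo sapiens) for inhibition, read by MTT assay, with a stated time of 48 h; a lower number here means a stronger inhibitor, a higher number a weaker inhibitor. Compound 1 `COc1ccc2c(=O)c(/C=C/C(=O)NCc3cccc(F)c3)coc2c1` gives 17600 nM and compound 2 `COc1ccc(NC(=O)/C=C/c2coc3cc(OC)ccc3c2=O)cc1` gives 13000 nM; the three numbers sit together, with a 1.1-fold higher number from compound 1 to compound 3 (0.04 log units; within the scatter) and a 1.5-fold higher number from compound 2 to compound 3 (0.17 log units; within the scatter), so compound 3 cannot be set apart from either. Compound 4 `COc1ccc2c(=O)c(/C=C/C(=O)Nc3ccc(F)cc3)coc2c1` is not yet measured; it differs from compound 3 by 4-fluorophenyl in place of 3-methoxyphenyl on an amide-type nitrogen. The nearest measured step is a 1.5-fold higher number from compound 2 to compound 3 (0.17 log units; within the scatter), where moving the methoxy group on the same ring changed little, and a 1.4-fold lower number from compound 1 to compound 2 (0.13 log units; within the scatter) shows that swapping the fluorine-bearing group for a methoxyphenyl also stayed within the scatter. No change beyond the scatter is therefore expected; compound 4 is estimated at 17000 nM, range 7000 nM to 45000 nM, a step of a 1.1-fold lower number from compound 3 to compound 4 (0.05 log units; within the scatter).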

Compound 4, half-maximal inhibitory concentration: 9680 nM
Compound 4: middle estimate off by 1.8-fold (0.24 log units), on the high side, within the range that was stated.
By their numbers in this assay, from the lowest: compounds 4, 2, 1 and 3 (each within the scatter of the next).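

In this assay, 4-fluorophenyl on the amide-type nitrogen stays within the scatter of all three earlier groups (a 2.0-fold lower number from compound 3 to compound 4 (0.30 log units; within the scatter); a 1.3-fold lower number from compound 2 to compound 4 (0.13 log units; within the scatter); a 1.8-fold lower number from compound 1 to compound 4 (0.26 log units; within the scatter)). The direct swap of fluoro in place of methoxy on an aromatic carbon is new here, and it too cannot be told from no change, so the four groups at this place remain unseparated. Nothing available explains why these groups read alike. Still open, from the compounds shown here alone, is whether any group here leaves the scatter, for example a ring carrying an amine or a carboxylic acid, or a longer chain on the nitrogen.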